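This account rests on a few compounds, and the source may have more. Where it says the series, first, only, none or still open, it means among the compounds named here.

Working notes on the series. Compound 1 `CCCCC(CC)C(=O)Nc1ccc2ccn(Cc3ccc(C(=O)NS(=O)(=O)c4ccccc4C)cc3OC)c2c1` carries 2-methylphenyl on the sulfonyl sulfur and gives 8.9 in a functional assay (trachea) for antagonist activity, with Cavia porcellus as the target; a lower number here means a less potent compound, a higher number a more potent compound, by a factor of ten per unit of this negative logarithm. Compound 2 `CCCCC(CC)C(=O)Nc1ccc2ccn(Cc3ccc(C(=O)NS(=O)(=O)c4ccc(OC)cc4)cc3OC)c2c1` gives 7.4 in this assay, and compound 3 `CCCCC(CC)C(=O)Nc1ccc2ccn(Cc3ccc(C(=O)NS(=O)(=O)c4ccc([N+](=O)[O-])cc4)cc3OC)c2c1` gives 7.7; compound 3 stands second highest of the three numbers, compound 2 nearest and compound 1 furthest. The steps of a number 1.50 log units lower from compound 1 to compound 2 (beyond the scatter) and a number 1.20 log units lower from compound 1 to compound 3 (beyond the scatter) are both large, whereas a number 0.30 log units higher from compound 2 to compound 3 (within the scatter) stays within the scatter. Compound 4 `CCCCC(CC)C(=O)Nc1ccc2ccn(Cc3ccc(C(=O)NS(=O)(=O)c4ccc(C)cc4)cc3OC)c2c1` differs from compound 3 by methyl in place of nitro on an aromatic carbon. Within the data shown here, a methyl at this place has no precedent. Because a number 0.30 log units higher from compound 2 to compound 3 (within the scatter) stayed within the scatter, the exchange to methyl in compound 4 is expected to remain small as well, a number 0.10 log units lower from compound 3 to compound 4 (within the scatter). Compound 4 is therefore estimated at 7.6, with a range from 7 to 8.4.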

Compound 4, negative logarithm of the antagonist equilibrium constant: 8.4
Compound 4: middle estimate off by 0.80 log units, on the low side; low and high end bracket the measured number.
By their numbers in this assay, from the lowest: compounds 2 and 3 (each within the scatter of the next); then compound 4; then compound 1.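

In this assay, the group on this aromatic carbon matters: methyl in place of nitro gives a number 0.70 log units higher from compound 3 to compound 4 (beyond the scatter), and methyl in place of methoxy gives a number 1.00 log units higher from compound 2 to compound 4 (beyond the scatter), although nitro and methoxy gave no separation beyond the scatter. The location of the methyl also counts, since 4-methylphenyl in place of 2-methylphenyl gives a number 0.50 log units lower from compound 1 to compound 4 (beyond the scatter). Nothing available explains these steps.

Open, on these data alone, is whether an ethyl chain, a chlorine or an amine in place of this methyl would track methyl or fall with nitro and methoxy.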